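The source may report more compounds than this note shows. Statements on the series, on what has been measured and on what is new or still open speak of the compounds shown alone.

Compound 1 `COc1cc(/C=C/COC(C)=O)ccc1OC(C)=O`: 9710 nM
Compound 2 `CCCC(=O)OC/C=C/c1ccc(OC(=O)CCC)c(OC)c1`: > 50000 nM

These values come from a functional assay on U-251 cells (Homo sapiens) for antiproliferative activity, read by sulforhodamine B assay, with a stated time of 72 h; a higher number here means a weaker inhibitor, a lower number a stronger inhibitor. For compound 2, > 50000 nM is a limit of the assay and not a number. Compound 3 `CCCC(=O)Oc1ccc(/C=C/COC(C)=O)cc1OC` differs from compound 2 by hydrogen in place of ethyl on a saturated chain carbon bound to a carbonyl carbon, so one propylcarbonyl becomes acetyl. Compound 3 therefore carries one acetyl, and the all-acetyl compound 1 gives 9710 nM. A moderate gain in strength is thus expected in this assay, an at least 2.5-fold lower number from compound 2 to compound 3 (0.39 log units; beyond the scatter). The estimate for compound 3 is 20000 nM, with an expected range of 8000 nM to 50000 nM.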

Compound 3, half-maximal inhibitory concentration: 45700 nM
Compound 3: the middle estimate sits 2.3-fold (0.36 log units) below what was measured; the range from low to high includes it.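

In this assay, the change on the saturated chain carbon bound to a carbonyl carbon now has a readable size: a 4.7-fold higher number from compound 1 to compound 3 (0.67 log units; beyond the scatter), so ethyl in place of hydrogen here, turning one acetyl into propylcarbonyl, weakens the compound beyond the scatter. The other step, an at least 1.0-fold lower number from compound 2 to compound 3 (0.03 log units; that floor lies within the scatter), gives only a floor. Compound 2 stands at a limit of the assay and not a number: the limit of > 50000 nM in this assay, at which 1 of the 3 values shown sits. From the compounds shown here alone, how much the second propylcarbonyl adds to the loss stays open. Also open, going by these compounds, is whether a longer chain or a carboxylic acid at this place would follow the same direction.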